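A few compounds are considered here, and "the series" means these few. Any claim that something is new, unique, unknown or untested is made for them only; others in the source may bear on it.

Measured so far:
compound 1 `Cc1ccc(NC(=O)C(=O)c2c[nH]c3cc(Cl)ccc23)cc1` gives 85.6%
compound 2 `Cc1ccc(NC(=O)C(=O)c2c[nH]c3cc(C(C)C)ccc23)cc1` gives 82.6%
Not yet measured: compound 3 `Cc1ccc(NC(=O)C(=O)c2c[nH]c3cc(C#N)ccc23)cc1`

In an ADME assay on microsomes from liver (Mus musculus) for metabolic stability, read by HPLC, with a stated time of 30 min (on this read-out higher numbers stand for a more stable compound and lower numbers for a less stable compound), compound 2 stands at 82.6% and lies within the scatter of compound 1. The next change is cyano in place of isopropyl on an aromatic carbon and reads cyano in place of isopropyl on an aromatic carbon. Among the measured compounds shown here, the one measured step is a number 3 percentage points lower from compound 1 to compound 2 (within the scatter) and puts isopropyl in place of chloro. For the measured compounds named here, no measured compound carries cyano, so that small step is the only guide. The expected change is a number 0.4 percentage points higher from compound 2 to compound 3 (within the scatter) and nothing beyond the scatter is anticipated. In this assay compound 3 is estimated at 83% with 72% to 93% as the expected range.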

Compound 3, percent of the compound remaining: 88.2%
Compound 3: the middle estimate sits 5.2 percentage points below what was measured, within the range that was stated.
By their numbers in this assay, from the lowest: compounds 2, 1 and 3 (each within the scatter of the next).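

Cyano joins chloro and isopropyl on this aromatic carbon, and this assay still separates none of them: the steps are a number 5.6 percentage points higher from compound 2 to compound 3 (within the scatter) and a number 2.6 percentage points higher from compound 1 to compound 3 (within the scatter) in the same series. Cyano, with its hydrogen-bond acceptor, therefore reads no differently from isopropyl, which has none, so this position has now accepted three different groups without a step beyond the scatter. Nothing available explains these numbers. From the compounds shown here alone, whether an amine, a carboxylic acid or a longer chain on this carbon would hold the same level remains open. So does whether this flat picture survives replacing the methyl group elsewhere on the shared core.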